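Intrinsic activity at the pendant aryl of the sulfonamide

A few compounds are considered here, and "the series" means these few. Any claim that something is new, unique, unknown or untested is made for them only; others in the source may bear on it.

The series shares one core and varies only the group on the far aromatic carbon of the sulfonyl-bearing ring. In a functional assay for agonist activity at growth hormone secretagogue receptor type 1 (Homo sapiens), read by FLIPR (a lower number here means a smaller maximal response, a higher number a larger maximal response), compound 1 `COc1ccc(N2C[C@@H](C)N[C@@H](C)C2)cc1NS(=O)(=O)c1ccc(-c2ccncc2)cc1` gives 0.7. Compound 2 `COc1ccc(N2C[C@@H](C)N[C@@H](C)C2)cc1NS(=O)(=O)c1ccc(-c2cncnc2)cc1` gives 0.6, and compound 3 `COc1ccc(N2C[C@@H](C)N[C@@H](C)C2)cc1NS(=O)(=O)c1ccc(-n2cccn2)cc1` gives 0.8. Between them, a number 0.10 lower from compound 1 to compound 2 (within the scatter) and a number 0.10 higher from compound 1 to compound 3 (within the scatter), while a number 0.20 higher from compound 2 to compound 3 (beyond the scatter). Compound 3 therefore carries the highest of the three numbers, with compound 1 within the scatter of it and compound 2 beyond it.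

Compound 4 `COc1ccc(N2C[C@@H](C)N[C@@H](C)C2)cc1NS(=O)(=O)c1ccc(Oc2ccccc2)cc1` is the next step from compound 3. The change is phenoxy in place of 1H-pyrazol-1-yl on an aromatic carbon. The three measured steps all exchange the group on this same aromatic carbon, para to a large group, and each of them moved this assay by a small to modest amount; none left the maximal response far from the range of compound 1, compound 2 and compound 3. A comparable step is expected here, and since the sense of the change cannot be read from a single neighbour, the estimate stays near the middle of the measured range with a small downward lean.

For compound 4 the expected value is 0.65, within 0.45 to 0.85, which corresponds to an expected a number 0.15 lower from compound 3 to compound 4 (beyond the scatter).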

Compound 4, intrinsic activity: the largest response reached, as a fraction of the reference agonist's: 0.9
Estimate against measurement, compound 4: 0.25 below, and the stated range ends below it.
By their numbers in this assay, from the lowest: compounds 2, 1, 3 and 4 (each within the scatter of the next, the first and the last beyond it).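

Notes on the pendant group: in this assay, phenoxy brings a six-membered aromatic ring of carbon only to this aromatic carbon, and the maximal response stays level with that of the 1H-pyrazol-1-yl group (a number 0.10 higher from compound 3 to compound 4 (within the scatter)), so a ring nitrogen is not required here for a response of this size. The same exchange does separate from both six-membered nitrogen rings (a number 0.20 higher from compound 1 to compound 4 (beyond the scatter); a number 0.30 higher from compound 2 to compound 4 (beyond the scatter)), whereas 1H-pyrazol-1-yl separates only from pyrimidin-5-yl, with pyridin-4-yl within the scatter of it. No supporting information on these compounds bears on why the response moves with these groups.

The compounds shown do not separate the contribution of the oxygen from that of the carbon-only ring, which a directly attached phenyl group would address, while a benzyloxy group would test a longer link to the same ring. Also open, on these data alone, is how substitution on the phenoxy ring, for example a fluorine or a methoxy group, or replacement of the ring by a saturated amine such as morpholine, would act on the maximal response.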